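Ethoxymethyl in Place of Tert-Butyl on a Shared Core

A few compounds are considered here, and "the series" means these few. Any claim that something is new, unique, unknown or untested is made for them only; others in the source may bear on it.

Of the compounds shown here, two have been measured in a functional assay for inhibition of Polyunsaturated fatty acid 5-lipoxygenase (Homo sapiens), in the absence of a further agent; on this read-out lower numbers stand for stronger inhibition and higher numbers for weaker inhibition. Compound 1 `COc1ccc(Cc2oc3c(Cl)cc(C(C)(C)C)c(O)c3c2C)cc1` gives 99 nM and compound 2 `CCCc1cc(Cl)c2oc(Cc3ccc(OC)cc3OC)c(C)c2c1O` gives 13 nM. For the measured compounds named here, compound 1 therefore stands at the higher of the two numbers, and the gap to compound 2 lies beyond the usual scatter; compound 2 differs from compound 1 in more than one place, so no single step between them is defined.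

Compound 3 `CCOCc1cc(Cl)c2oc(Cc3ccc(OC)cc3)c(C)c2c1O` has not yet been measured. It differs from compound 1 in one place: ethoxymethyl in place of tert-butyl on an aromatic carbon. Going by the values given here, no measured pair shows this exchange on its own, so the expected size of the step rests only on the two numbers known. The step from compound 1 to compound 3 is expected to be a 1.7-fold lower number from compound 1 to compound 3 (0.22 log units; within the scatter), with a lower number held more likely than a higher one but not clearly beyond the scatter. On this basis compound 3 is estimated to give 60 nM, within a range from 15 nM to 250 nM.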

Compound 3, half-maximal inhibitory concentration: 291 nM
Estimate against measurement, compound 3: 4.9-fold (0.69 log units) below, outside the stated range (above it).
By their numbers in this assay, from the lowest: compound 2; then compound 1; then compound 3.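

In this assay, the aromatic carbon ortho to the hydroxy group responds to this exchange: ethoxymethyl in place of tert-butyl gives a 2.9-fold higher number from compound 1 to compound 3 (0.47 log units; beyond the scatter). The step is beyond the scatter even though the heavy-atom count stays the same, with an oxygen entering the group and a hydrogen-bond acceptor gained. The data shown offer no measurement that accounts for this step.

The compounds shown leave open whether the step follows the oxygen in the chain or the loss of the branched tert-butyl shape, a question that a plain butyl chain at this position would bear on. From the compounds shown here alone, it also remains open how an amine or a carboxylic acid on the same carbon would read out in this assay.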